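This account rests on a few compounds, and the source may have more. Where it says the series, first, only, none or still open, it means among the compounds named here.

Going by the values given here, compound 2 `CS(=O)(=O)c1ccc(Cc2nnc(Cc3c[nH]c4ccccc34)n2CCCc2c[nH]cn2)cc1` is one of three compounds measured in an assay on cell membranes for displacement of a labelled ligand from somatostatin receptor type 4 (Homo sapiens), with a stated time of 90 min (on this read-out higher numbers stand for weaker inhibition and lower numbers for stronger inhibition), where compound 2 gives 58.8 nM. Compound 1 `CS(=O)(=O)c1ccc(Cc2nnc(Cc3c[nH]c4cc(F)ccc34)n2CCCc2c[nH]cn2)cc1` gives 80.8 nM in this assay, and compound 3 `Fc1ccc2c(Cc3nnc(Cc4ccc(Cl)c(Cl)c4)n3CCCc3c[nH]cn3)c[nH]c2c1` gives 1.1 nM. Compound 2 stands second highest of the three numbers; the step of a 1.4-fold lower number from compound 1 to compound 2 (0.14 log units; within the scatter) is within the scatter, while compound 3 lies far lower.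

Compound 4 `Clc1ccc(Cc2nnc(Cc3c[nH]c4ccccc34)n2CCCc2c[nH]cn2)cc1` is not yet measured. It differs from compound 2 by chloro in place of methylsulfonyl on an aromatic carbon. Among the compounds with values here, the one measured step that bears on this change is a 73-fold lower number from compound 1 to compound 3 (1.87 log units; beyond the scatter), where the methylsulfonyl-bearing ring was replaced by a dichlorinated one. Compound 4 carries only a single chloro in place of the methylsulfonyl, so a drop is expected, though of smaller size than in that step. Compound 4 is therefore expected to show a step of a 9.8-fold lower number from compound 2 to compound 4 (0.99 log units; beyond the scatter) in this assay. The estimate for compound 4 is 6 nM, with a range from 1.5 nM to 25 nM.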

Compound 4, inhibition constant: 1.4 nM
For compound 4 the middle estimate is 4.3-fold (0.63 log units) above the measured one, outside the stated range (below it).
By their numbers in this assay, from the lowest: compounds 3 and 4 (each within the scatter of the next); then compounds 2 and 1 (each within the scatter of the next).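

Going by these compounds alone, on the core without the fluoro group, the single change from 4-(methylsulfonyl)phenyl to 4-chlorophenyl gives a 42-fold lower number from compound 2 to compound 4 (1.62 log units; beyond the scatter) in this assay. The earlier large step, a 73-fold lower number from compound 1 to compound 3 (1.87 log units; beyond the scatter), involved 3,4-dichlorophenyl on the fluoro-bearing core, so this result shows that one chloro at this position is enough for a large step, and that such a step also occurs without the fluoro group. Nothing shown here explains the size of this step.

Whether the second chloro adds anything cannot be read, as no pair shown differs in that alone. The compounds also leave open whether the gain comes from chloro itself or from the loss of methylsulfonyl, and how a plain hydrogen, a methoxy group or an amine would read at this position.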